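Working notes: aryl swap at the ring amine nitrogen

A few compounds are considered here, and "the series" means these few. Any claim that something is new, unique, unknown or untested is made for them only; others in the source may bear on it.

Compound 1 `Nc1scc(CN2CCN(c3ccc(Cl)cc3F)CC2)c1C(=O)c1ccc(Cl)cc1`: in an assay on CHO cells for displacement of a labelled ligand from adenosine receptor A3 (Homo sapiens), read by scintillation counting, with a stated time of 120 min, tested at 10 uM (on this read-out higher numbers stand for more inhibition at the one concentration tested (going by the name of the read-out) and lower numbers for less inhibition), compound 1 gives 1%.
Compound 2 `Nc1scc(CN2CCN(c3ccccc3F)CC2)c1C(=O)c1ccc(Cl)cc1`: compound 2 gives 0%.
Compound 3 `Nc1scc(CN2CCN(c3ccc(F)cc3F)CC2)c1C(=O)c1ccc(Cl)cc1`: compound 3 gives 0%.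

Compound 3 sits level with compound 2 at the digits shown, the two lowest of the three, with no change at the digits printed from compound 2 to compound 3 (within the scatter) and a number 1 percentage points lower from compound 1 to compound 3 (within the scatter). The whole series stays near zero.

Compound 4 `Nc1scc(CN2CCN(c3cccc(Cl)c3)CC2)c1C(=O)c1ccc(Cl)cc1` changes the aryl group: 3-chlorophenyl in place of 2,4-difluorophenyl on an amine nitrogen in a ring. The measured steps, a number 1 percentage points lower from compound 1 to compound 2 (within the scatter) and a number 1 percentage points lower from compound 1 to compound 3 (within the scatter), vary only halogens on that ring and all lie within the scatter; none exchanges the ring itself, so they bear on compound 4 only loosely. Among the compounds with values here, with every value so far near zero, no step beyond the scatter is expected, a number 1 percentage points higher from compound 3 to compound 4 (within the scatter). Compound 4 is estimated at 1%, range -5% to 10%.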

Compound 4, a percentage reported as inhibition, at one concentration (the size of the read-out at that concentration, not a potency): 1%
For compound 4 middle estimate and measured number coincide at the digits printed; the range from low to high includes it.
By their numbers in this assay, from the lowest: compounds 2, 3, 1 and 4 (each within the scatter of the next).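

Replacing the whole aryl group on the ring amine nitrogen, and not only varying its halogens, also leaves the read-out in this assay within the scatter, with a number 1 percentage points higher from compound 3 to compound 4 (within the scatter), with a number 1 percentage points higher from compound 2 to compound 4 (within the scatter) and with no change at the digits printed from compound 1 to compound 4 (within the scatter). At this position, 3-chlorophenyl therefore does not separate from 2,4-difluorophenyl, 2-fluorophenyl or 4-chloro-2-fluorophenyl. Nothing available gives a reason for this flat result.

Still open, as far as these compounds go, is whether an amine or a carboxylic acid on this aryl group would move the number beyond the scatter. The same question applies to a longer chain in place of the aryl group.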